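The source may hold more compounds than are shown below. What is called first, only, known or untested is meant among the compounds shown, and "the series" means these compounds.

In an ADME assay on cells (Hepatocyte, Mus musculus) for metabolic stability, with a stated time of 30 min (a higher number here means that more of the compound is left, a lower number that less of the compound is left), compound 1 (`O=C(NC1CCC(CN2CCN(c3cc(=O)c4cc(C(F)(F)F)cc([N+](=O)[O-])c4s3)CC2)CC1)c1ccccc1`) stands highest of three, at 90.6% against compound 3 (`Nc1cc(C(F)(F)F)cc2c(=O)cc(N3CCN(CC4CCCCC4)CC3)sc12`) at 69.4% and compound 2 (`O=c1cc(N2CCN(CC3CCCCC3)CC2)sc2c(NO)cc(C(F)(F)F)cc12`) at 47.8% as the lowest. Compound 4 (`O=C(OC1CCC(CN2CCN(c3cc(=O)c4cc(C(F)(F)F)cc([N+](=O)[O-])c4s3)CC2)CC1)C1CCCCC1`) carries (cyclohexylcarbonyl)oxy in place of benzamido on a saturated ring carbon. Among the measured compounds shown here, the only measured step (a number 21.6 percentage points higher from compound 2 to compound 3 (beyond the scatter)) puts hydrogen in place of hydroxy on a nitrogen on an aromatic ring, so it does not cover this change and serves only as a guide to size. With compound 1 at 90.6% little room lies above it, so a modest fall of that order is expected. The expected step is downward (a number 25.6 percentage points lower from compound 1 to compound 4 (beyond the scatter)). For compound 4 the estimate is 65% (expected range 40% to 88%).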

Compound 4, percent of the compound remaining: 1.2%
Compound 4: the middle estimate sits 63.8 percentage points above what was measured; measured number outside the range, below it.
By their numbers in this assay, from the lowest: compound 4; then compound 2; then compound 3; then compound 1.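

In this assay, (cyclohexylcarbonyl)oxy in place of benzamido on a saturated ring carbon gives a large fall (a number 89.4 percentage points lower from compound 1 to compound 4 (beyond the scatter)). Among the compounds shown here, that exceeds the only earlier step, on a nitrogen on an aromatic ring (a number 21.6 percentage points higher from compound 2 to compound 3 (beyond the scatter)), so the group at this saturated ring carbon can shift the read-out strongly. Nothing measured here bears on what lies behind the fall. The change swaps the linking nitrogen for oxygen and the aromatic ring for a saturated one together. A cyclohexanecarboxamide or a benzoate ester would be needed to separate the two.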